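The source may report more compounds than this note shows. Statements on the series, on what has been measured and on what is new or still open speak of the compounds shown alone.

Working notes on the series. Compound 1 `COc1ccc(/C=C\c2cc(OC)c(OC)c(OC)c2)cc1OCc1ccc(C=O)cc1` gives 46000 nM in an ADME assay on HEK293 cells (Homo sapiens) for cytotoxicity, read by CCK-8 assay, with a stated time of 48 h (on this read-out lower numbers stand for stronger inhibition and higher numbers for weaker inhibition), the highest of the two numbers shown; its nearest neighbour is compound 2 `COc1ccc(/C=C\c2cc(OC)c(OC)c(OC)c2)cc1OCc1ccc(CN2CCCC[C@@H]2C(=O)O)cc1`, which in this assay gives 42000 nM. The step of a 1.1-fold lower number from compound 1 to compound 2 (0.04 log units; within the scatter) is small. Compound 3 `COc1ccc(/C=C\c2cc(OC)c(OC)c(OC)c2)cc1OCc1ccc(CN2CC[C@H](O)C2)cc1` is reported in this assay only as a limit, > 50000 nM. This is one of the limit of > 50000 nM in this assay, at which 1 of the 3 values shown sits. The steps of an at least 1.0-fold higher number from compound 1 to compound 3 (0.03 log units; that floor lies within the scatter) and an at least 1.1-fold higher number from compound 2 to compound 3 (0.07 log units; that floor lies within the scatter) are bounds only.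

Compound 4 `COc1ccc(/C=C\c2cc(OC)c(OC)c(OC)c2)cc1OCc1ccc(CNCCNC(C)=O)cc1` differs from compound 1 in ((2-acetamidoethyl)amino)methyl in place of formyl on an aromatic carbon. Both measured replacements of the formyl group stayed within the scatter, so no step beyond the scatter is expected for compound 4, that is a 1.0-fold higher number from compound 1 to compound 4 (0.01 log units; within the scatter). In this assay compound 4 is estimated at 47000 nM, with a range from 25000 nM to 90000 nM.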

Compound 4, half-maximal inhibitory concentration: > 50000 nM
Compound 4: no number, only a limit; the forecaster's own chance of this, stated with the estimate: 40%; at least 1.0-fold (0.02 log units) between middle value and limit.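

The open-chain ((2-acetamidoethyl)amino)methyl, with no ring, behaves in this assay like the ring-bearing replacements of formyl: the steps of an at least 1.0-fold higher number from compound 1 to compound 4 (0.03 log units; that floor lies within the scatter) and an at least 1.1-fold higher number from compound 2 to compound 4 (0.07 log units; that floor lies within the scatter) show no change beyond the scatter. The value of compound 4 is a limit and not a number, so the step between compound 3 and compound 4 cannot be read. Compound 4 therefore sits with compound 3 at the ceiling of the assay: the limit of > 50000 nM in this assay, at which 2 of the 4 values shown sit.

Open, from the compounds shown here alone, is how far compound 3 and compound 4 lie past that limit. Also open, going by these compounds, is whether a primary amine or a sulfonamide in place of formyl would give a step beyond the scatter.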